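Two Pyrazole Chalcones and a Third, Still Unmeasured

The source may hold more compounds than are shown below. What is called first, only, known or untested is meant among the compounds shown, and "the series" means these compounds.

Measured so far:
compound 1, `COc1cc(-c2cc(/C=C/C(=O)c3ccc(N)cc3)[nH]n2)cc(OC)c1OC`, 91%
compound 2, `COc1ccc(-c2cc(/C=C/C(=O)c3ccc(OC)c(OC)c3)[nH]n2)cc1`, 88%
compound 3, `COc1ccc(-c2cc(/C=C/C(=O)c3ccc(N)cc3)[nH]n2)cc1`, 94%

In a functional assay on MCF7 cells (Homo sapiens) for cytotoxicity, read by sulforhodamine B assay, with a stated time of 48 h, tested at 0.1 uM (a higher number here means a weaker effect of the compound at the concentration tested, a lower number a stronger effect), compound 1 gives 91%. Among the three numbers it sits in the middle: the nearest is compound 2, and compound 3 lies on the other side, both within the usual scatter of this kind of measurement. All three compounds are, at this concentration, weak, and nothing separates them beyond the scatter.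

Compound 4, `COc1ccc(C(=O)/C=C/c2cc(-c3cc(OC)c(OC)c(OC)c3)n[nH]2)cc1OC`, has not yet been measured in this assay. It differs from compound 1 in one place: 3,4-dimethoxyphenyl in place of 4-aminophenyl on a carbonyl carbon. Among the measured compounds shown here, no step between two measured compounds is known for this change on the core of compound 1. Compound 3 and compound 2, which share a different core, carry the two groups in question, and their values lie within the scatter of each other. Compound 4 is therefore expected to stay close to compound 1, with the step of a number 4 percentage points lower from compound 1 to compound 4 (within the scatter) not reaching beyond the scatter. The estimate for compound 4 is 87%, with a range from 78% to 96%.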

Compound 4, a percentage reported as activity, at one concentration (the size of the read-out at that concentration, not a potency): 91%
The estimate for compound 4 lay 4 percentage points below the measured number; measured number inside the range.
By their numbers in this assay, from the lowest: compounds 2, 1, 4 and 3 (each within the scatter of the next).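

In this assay the exchange of 4-aminophenyl for 3,4-dimethoxyphenyl on a carbonyl carbon brings no change at the digits printed from compound 1 to compound 4 (within the scatter) on the core of compound 1. Among the compounds shown here, this gives the first direct reading of the change on that core: with 10 heavy atoms entering and 7 leaving, and 0 hydrogen-bond donors in place of 1, the read-out does not separate the two groups. No measured evidence at hand accounts for this result.

The compounds shown leave open whether a different kind of group on this carbonyl carbon, such as a carboxylic acid or a longer alkyl chain in place of the aromatic ring, would move the number beyond the scatter. They also leave open whether the two aromatic groups would still read alike at another concentration, since a reading at one concentration gives no potency.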